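From acetamido to sulfonylcarbamoyl on the shared core

A few compounds are considered here, and "the series" means these few. Any claim that something is new, unique, unknown or untested is made for them only; others in the source may bear on it.

Among the measured compounds shown here, compound 1 `CC(=O)Nc1ccc2c(cnn2CC(=O)COc2ccc(Oc3ccccc3)cc2)c1` gives 3900 nM in an assay on microsomes from brain for inhibition of Fatty-acid amide hydrolase 1 (Rattus norvegicus), read by fluorescence and HPLC, with a stated time of 45 min (a higher number here means a weaker inhibitor, a lower number a stronger inhibitor), the highest of the two numbers so far; its nearest neighbour is compound 2. Compound 2 `CS(=O)(=O)NC(=O)c1ccc2c(cnn2CC(=O)COc2ccc(Oc3ccccc3)cc2)c1` gives 770 nM in this assay. For the measured compounds named here, the single measured step, a 5.1-fold lower number from compound 1 to compound 2 (0.70 log units; beyond the scatter), is the only one that bears on the new compound.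

Compound 3 `O=C(COc1ccc(Oc2ccccc2)cc1)Cn1ncc2cc(C(=O)NS(=O)(=O)C(F)(F)F)ccc21` is not yet measured. It differs from compound 1 in one place: ((trifluoromethyl)sulfonyl)carbamoyl in place of acetamido on an aromatic carbon. The change matches the measured step in kind, a sulfonylcarbamoyl entering where acetamido leaves, differing only in the trifluoromethyl in place of methyl on the sulfonyl. Going by the values given here, a lowering of the number in this assay of about the same size is therefore expected, beyond the scatter, with no measured compound showing how the trifluoromethyl itself shifts the result.

Compound 3 is thus expected to give 500 nM in this assay, within 150 nM to 1800 nM. The expected step is a 7.8-fold lower number from compound 1 to compound 3 (0.89 log units; beyond the scatter).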

Compound 3, half-maximal inhibitory concentration: 510 nM
Compound 3: middle estimate off by 1.0-fold (0.01 log units), on the low side; measured number inside the range.
By their numbers in this assay, from the lowest: compounds 3 and 2 (each within the scatter of the next); then compound 1.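

Replacing acetamido with a sulfonylcarbamoyl on this aromatic carbon now lowers the number with a second sulfonyl substituent in this assay (a 7.6-fold lower number from compound 1 to compound 3 (0.88 log units; beyond the scatter)), so the lowering seen with compound 2 is not confined to the methyl form. Trifluoromethyl in place of methyl on the sulfonyl sulfur stays within the scatter (a 1.5-fold lower number from compound 2 to compound 3 (0.18 log units; within the scatter)), so this assay does not separate these two substituents. No measurement on hand bears on why the two sulfonylcarbamoyl compounds give lower numbers than compound 1.

The compounds shown leave open how a carboxylic acid on this aromatic carbon would compare with the sulfonylcarbamoyl groups, and so whether the sulfonyl is needed at all. Also open, going by these compounds, is whether a longer alkyl chain or a phenyl on the sulfonyl sulfur would keep the number in the same range.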